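The source may report more compounds than this note shows. Statements on the series, on what has been measured and on what is new or still open speak of the compounds shown alone.

Measured so far:
compound 1 `C=C[C@@](C)(/C=C/c1ccc(OCc2ccccc2)cc1)CCC=C(C)C` — > 36600 nM
compound 2 `C=C[C@@](C)(/C=C/c1ccc(O)c(/C=C/C(=O)c2ccccc2)c1)CCC=C(C)C` — > 20000 nM

In an ADME assay on BJ cells (Homo sapiens) for cytotoxicity, with a stated time of 72 h (on this read-out lower numbers stand for an effect already at smaller amounts and higher numbers for an effect only at larger amounts of compound), compound 1 gives only a limit, > 36600 nM, not a number. Compound 2 likewise gives only a limit in this assay, > 20000 nM. Compound 1 therefore stands at a limit of > 36600 nM in this assay, at which 1 of the 2 values shown sits, with no definite place on the scale. Compound 3 `C=C[C@@](C)(/C=C/c1ccc(Nc2ccc(F)cc2)cc1)CCC=C(C)C` carries the change ((4-fluorophenyl)amino in place of benzyloxy on an aromatic carbon). For the measured compounds named here, no step between measured compounds is known, so the step in this assay is expected to stay within the scatter, with a limit likely again: an at least 1.2-fold lower number from compound 1 to compound 3 (0.08 log units; that floor lies within the scatter). Compound 3 is estimated at 30000 nM, in the range 8000 nM to 60000 nM.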

Compound 3, half-maximal effective concentration: > 36600 nM
Compound 3 was reported as a limit; the forecaster's own chance of this, stated with the estimate: 60%; middle value at least 1.2-fold (0.08 log units) from the limit.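

In this assay compound 1 gives only a limit, > 36600 nM. Compound 3 also gives only a limit, > 36600 nM, so no step can be read between compound 1 and compound 3. From the compounds shown here alone, whether (4-fluorophenyl)amino in place of benzyloxy on an aromatic carbon shifts the read-out in either direction stays open.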